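The source may hold more compounds than are shown below. What is called first, only, known or untested is meant among the compounds shown, and "the series" means these compounds.

In a functional assay on A549 cells (Homo sapiens) for cytotoxicity, read by MTT assay, with a stated time of 72 h (on this read-out lower numbers stand for stronger inhibition and higher numbers for weaker inhibition), compound 1 `Cc1c(C(=O)Nc2ccc(Oc3ccnc4[nH]ccc34)c(F)c2)nnn1-c1ccc(F)cc1` gives 150 nM. Compound 2 `Cc1c(C(=O)Nc2ccc(Oc3ccnc4[nH]ccc34)c(F)c2)nnn1-c1ccc(F)c(Cl)c1` gives 730 nM in this assay; it differs from compound 1 by chloro in place of hydrogen on an aromatic carbon, and the measured step is a 4.9-fold higher number from compound 1 to compound 2 (0.69 log units; beyond the scatter). Compound 3 `O=C(Nc1ccc(Oc2ccnc3[nH]ccc23)cc1)c1nnn(-c2ccc(F)cc2)c1C(F)(F)F` gives 180 nM in this assay; how its core differs from the core of compound 1 is not broken down here. Compound 4 `O=C(Nc1ccc(Oc2ccnc3[nH]ccc23)cc1)c1nnn(-c2ccc(F)c(Cl)c2)c1C(F)(F)F` has not yet been measured in this assay. Among the measured compounds shown here, it differs from compound 3 by chloro in place of hydrogen on an aromatic carbon, which is the same change as the one between compound 1 and compound 2, made at a place described in the same words. For the measured compounds named here, because the only measured example of this change is a 4.9-fold higher number from compound 1 to compound 2 (0.69 log units; beyond the scatter), a step of similar size is expected for compound 4, a 4.4-fold higher number from compound 3 to compound 4 (0.65 log units; beyond the scatter). The estimate for compound 4 in this assay is accordingly 800 nM, with a likely range from 300 nM to 2500 nM.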

Compound 4, half-maximal inhibitory concentration: 1120 nM
The estimate for compound 4 lay 1.4-fold (0.15 log units) below the measured number; measured number inside the range.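

In this assay, the change from 4-fluorophenyl to 3-chloro-4-fluorophenyl gave a 6.2-fold higher number from compound 3 to compound 4 (0.79 log units; beyond the scatter). The change therefore carried over from one core to the other with much the same size: the same change on two cores in this assay, a 4.9-fold higher number (0.69 log units; beyond the scatter) from compound 1 to compound 2 and a 6.2-fold higher number (0.79 log units; beyond the scatter) from compound 3 to compound 4, 1.3-fold (0.11 log units) apart, within the scatter of two such steps. Among the compounds shown here, this rests on only two pairs in a single cell assay, so it does not show that the step would hold on other cores, and it does not explain why the number rises. The compounds shown leave open whether another group at the same place, such as bromo, methyl, methoxy or an amine, would give a similar step. They also leave open whether chloro would have the same effect without the neighbouring fluoro group.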